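A few compounds are considered here, and "the series" means these few. Any claim that something is new, unique, unknown or untested is made for them only; others in the source may bear on it.

Measured so far in a physicochemical assay for lipophilicity, using the shake flask method, measured as octanol-water partition, at pH 7.4; a higher number here means a more lipophilic compound, a lower number a more polar compound:
compound 1 `CC(=O)N[C@@H]1CCC[C@H](C(=O)Nc2cc(-c3cnc(C)n3C(C)C)ccn2)C1`: 1.9
compound 2 `CC(=O)N[C@@H]1CCC[C@H](C(=O)Nc2cc(-c3nnn4ccccc34)c(Cl)cn2)C1`: 2

Compound 2 holds the higher of the two numbers in this assay, but its nearest neighbour is compound 1, and the gap between the two lies within the scatter of repeated measurements, so the two compounds cannot be ordered on these data. For the measured compounds named here, both share the same core, and nothing measured so far separates them.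

Compound 3 `CC(=O)N[C@@H]1CCC[C@H](C(=O)Nc2cc(-c3cnn4c3OCCC4)c(Cl)cn2)C1` has not yet been measured in this assay. It differs from compound 2 in one place: a group of 9 heavy atoms (6 carbon, 2 nitrogen, 1 oxygen; one five-membered aromatic ring with 2 hetero atoms, one six-membered non-aromatic ring with 2 hetero atoms) in place of a group of 9 heavy atoms (6 carbon, 3 nitrogen; one five-membered aromatic ring with 3 hetero atoms, one six-membered aromatic ring with 1 hetero atom), on an aromatic carbon. The group that leaves and the group that enters are of the same size and carry the same number of hydrogen-bond acceptors; the change trades one five-membered aromatic ring with 3 hetero atoms and one six-membered aromatic ring with 1 hetero atom for one five-membered aromatic ring with 2 hetero atoms and one six-membered non-aromatic ring with 2 hetero atoms, on an aromatic carbon of the core.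

Going by the values given here, no step between measured compounds of this kind is available to calibrate the change. The expectation is that the step from compound 2 to compound 3, no change at the digits printed from compound 2 to compound 3 (within the scatter), stays within the scatter, with no clear direction. Compound 3 is therefore estimated at 2 in this assay, with a range from 1.5 to 2.5.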

Compound 3, distribution coefficient: 2.6
Beside the measured number, compound 3's estimate is 0.60 log units below it, and the stated range ends below it.
By their numbers in this assay, from the lowest: compounds 1 and 2 (each within the scatter of the next); then compound 3.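

In this assay, the aromatic carbon ortho to a chloro group and opposite the ring nitrogen now proves responsive to the group it carries: a number 0.60 log units higher from compound 2 to compound 3 (beyond the scatter). The leaving and entering groups match in heavy-atom count and in hydrogen-bond donors and acceptors, so those counts alone do not fix the number at this position; the visible difference lies in the atoms and rings, with one five-membered aromatic ring with 2 hetero atoms and one six-membered non-aromatic ring with 2 hetero atoms replacing one five-membered aromatic ring with 3 hetero atoms and one six-membered aromatic ring with 1 hetero atom. Nothing available explains why the number moves with this exchange.

Open, on these data alone, is whether the step follows the ring oxygen or the non-aromatic ring as a whole, which a methylene group in place of that oxygen would help separate, and whether an amine on the same ring would shift the number in the other direction. Also open, as far as these compounds go, is whether the same exchange gives a step of similar size on a core without the chloro group.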